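This account rests on a few compounds, and the source may have more. Where it says the series, first, only, none or still open, it means among the compounds named here.

Working notes on the series.

Of the compounds shown here, two have numbers so far. Compound 1 `Cc1ccc(-c2nc(C)c([C@H](OC(C)(C)C)C(=O)O)c(-c3ccc4c(c3)CCCO4)c2C)cc1` gives 0.717 h in an ADME assay (liver) for metabolic stability, with Liver microsome (Homo sapiens) as the target, using microsomes; on this read-out higher numbers stand for a longer-lived compound and lower numbers for a shorter-lived compound. Compound 2 `Cc1ccc(-c2nc(C)c([C@H](OC(C)(C)C)C(=O)O)c(-c3ccc(Cl)cc3)c2C)cc1C` gives 1.28 h in this assay, the higher of the two figures, though its gap to compound 1 lies within the usual scatter, so the two are not separated.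

Compound 3 `Cc1ccc(-c2nc(C)c([C@H](OC(C)(C)C)C(=O)O)c(-c3ccc4c(c3Cl)NCCO4)c2C)cc1C` has not been run in this assay. It differs from compound 2 in one place: a group of 11 heavy atoms (8 carbon, 1 nitrogen, 1 oxygen, 1 chlorine; one six-membered non-aromatic ring with 2 hetero atoms, one six-membered aromatic ring of carbon only) in place of a group of 7 heavy atoms (6 carbon, 1 chlorine; one six-membered aromatic ring of carbon only), on an aromatic carbon. Within the data shown here, the group that enters carries a ring like the one in compound 1, while compound 2 keeps a plain aromatic ring with a chlorine; compound 1 sits at the lower of the two known values. Among the measured compounds shown here, no step between measured compounds exists here, so the size of the change cannot be read off directly, and only a small step is expected, downward or none beyond the scatter: the estimated step from compound 2 to compound 3 is a 1.4-fold lower number from compound 2 to compound 3 (0.15 log units; within the scatter). Compound 3 is therefore expected to give about 0.9 h in this assay, most likely between 0.4 h and 2 h.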

Compound 3, half-life: 1.7 h
Compound 3: middle estimate off by 1.9-fold (0.28 log units), on the low side; low and high end bracket the measured number.
By their numbers in this assay, from the lowest: compounds 1, 2 and 3 (each within the scatter of the next, the first and the last beyond it).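

In this assay, replacing the 4-chlorophenyl group on the aromatic carbon opposite the ring nitrogen with the larger entering group gives a 1.3-fold higher number from compound 2 to compound 3 (0.12 log units; within the scatter). This position therefore accepts a group with a second, non-aromatic ring with 2 hetero atoms, 1 hydrogen-bond donor and 2 hydrogen-bond acceptors, while compound 3 stays unseparated from compound 2 on this read-out. No data at hand bear on the reason for this result.

The compounds shown do not separate the share of the chlorine from that of the non-aromatic ring within the entering group, as both arrive in a single change. Also open, on these data alone, is how a simple amine or a carboxylic acid on the same aromatic ring would read in this assay.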